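Working notes: chloro in place of nitro, compound 4

The source may report more compounds than this note shows. Statements on the series, on what has been measured and on what is new or still open speak of the compounds shown alone.

In an ADME assay on MT4 cells (Homo sapiens) for cytotoxicity, read by MTT assay, with a stated time of 96 h (on this read-out lower numbers stand for higher toxicity in this test and higher numbers for lower toxicity in this test), compound 1 `COc1ccc(/N=N/N2CCCC2)cc1` gives 68000 nM. Compound 3 `CN(C)CCCN(/N=N/c1ccccc1)c1cccc(C(F)(F)F)c1` gives 14000 nM, but its structure departs from the shared core of compound 1 in more than one place, so it says little about the present change.

Compound 2 `O=[N+]([O-])c1ccc(/N=N/N2CCCC2)cc1` gives >= 100000 nM, which is a limit of the assay and not a number. Compound 2 therefore stands at the limit of >= 100000 nM in this assay, at which 1 of the 3 values shown sits, and any step from it is counted from that limit.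

Compound 4 `Clc1ccc(/N=N/N2CCCC2)cc1` has not yet been measured in this assay. It carries chloro in place of nitro on an aromatic carbon.

Within the data shown here, only one measured step changes this same place, namely nitro in place of methoxy, with an at least 1.4-fold higher number from compound 1 to compound 2 (0.16 log units; that floor lies within the scatter). Among the measured compounds shown here, that step shows no change beyond the scatter, and no chloro compound has been measured for comparison. Taken with compound 1 at 68000 nM, this points to a small step towards a lower number, possibly none beyond the scatter. The estimated step is an at least 1.4-fold lower number from compound 2 to compound 4 (0.15 log units; that floor lies within the scatter).

For compound 4 the estimate is 70000 nM, with an expected range from 30000 nM to 100000 nM.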

Compound 4, half-maximal cytotoxic concentration: > 100000 nM
Compound 4 ended at the assay's limit (the forecaster's own chance of this, stated with the estimate: 30%); middle value at least 1.4-fold (0.15 log units) away from the limit.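

With chloro on the aromatic carbon para to a group of 7 heavy atoms, compound 4 in this assay gives > 100000 nM, which is a limit of the assay and not a number. Chloro in place of methoxy gives an at least 1.4-fold higher number from compound 1 to compound 4 (0.16 log units; that floor lies within the scatter), so this place now has a second replacement of methoxy that shows no step beyond the scatter, alongside nitro with an at least 1.4-fold higher number from compound 1 to compound 2 (0.16 log units; that floor lies within the scatter). Nitro and chloro cannot be ordered at this place, and the step between compound 2 and compound 4 cannot be read, with compound 4 standing at a limit: the limit of > 100000 nM in this assay, at which 1 of the 4 values shown sits.

On these data alone, it remains open how the shared core behaves in this test once the group on this aromatic carbon is neither methoxy, nitro nor chloro, and whether any such group gives a number that can be read against compound 1 beyond the scatter. An amine or a carboxylic acid at the same place would test this, since either would give a comparison with compound 1 that differs in this one place only.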